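A thiazole gives way to an oxadiazole

A few compounds are considered here, and "the series" means these few. Any claim that something is new, unique, unknown or untested is made for them only; others in the source may bear on it.

In a functional assay on HepG2 cells (Homo sapiens) for inhibition, read by MTT assay, with a stated time of 48 h, tested at 2 uM (on this read-out lower numbers stand for less inhibition and higher numbers for more inhibition at the one concentration tested (going by the name of the read-out)), compound 2 `Cc1noc(C)c1-c1ccc2c(c1)C(c1ccccc1)N(Cc1nc(-c3ccc(F)cc3)cs1)C(=O)N2C` gives 41.1%, the highest of the two numbers at hand. Among the measured compounds shown here, its only measured neighbour, compound 1 `Cc1nc(-c2ccccc2)sc1CN1C(=O)N(C)c2ccc(-c3c(C)noc3C)cc2C1c1ccccc1`, gives 29.2%; the step of a number 11.9 percentage points higher from compound 1 to compound 2 (beyond the scatter) came with 4-(4-fluorophenyl)-1,3-thiazol-2-yl in place of 4-methyl-2-phenyl-1,3-thiazol-5-yl on a saturated chain carbon bound to an amide-type nitrogen in a ring. Compound 3 `Cc1noc(C)c1-c1ccc2c(c1)C(c1ccccc1)N(Cc1nnc(-c3ccc(F)cc3)o1)C(=O)N2C` has not been measured. It differs from compound 2 in one place: 5-(4-fluorophenyl)-1,3,4-oxadiazol-2-yl in place of 4-(4-fluorophenyl)-1,3-thiazol-2-yl on a saturated chain carbon bound to an amide-type nitrogen in a ring. The five-membered ring on that carbon is exchanged while the 4-fluorophenyl group stays. For the measured compounds named here, only the step from compound 1 to compound 2 touches the same place, and it exchanged a differently substituted thiazole rather than the ring type itself, so it bears on this change only loosely; no measured pair exchanges a thiazole for an oxadiazole. With nothing pointing clearly either way, the step expected in a number 3.1 percentage points lower from compound 2 to compound 3 (within the scatter) is none beyond the scatter. From the compounds shown here alone, compound 3 is therefore estimated at 38%, within 20% to 56%, a range kept wide because the ring exchange itself is untested.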

Compound 3, a percentage reported as inhibition, at one concentration (the size of the read-out at that concentration, not a potency): 52.8%
Beside the measured number, compound 3's estimate is 14.8 percentage points below it, within the range that was stated.
By their numbers in this assay, from the lowest: compound 1; then compound 2; then compound 3.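

The five-membered ring on the saturated chain carbon bound to an amide-type nitrogen in a ring matters in its own right: in this assay, exchanging 4-(4-fluorophenyl)-1,3-thiazol-2-yl for 5-(4-fluorophenyl)-1,3,4-oxadiazol-2-yl gave a number 11.7 percentage points higher from compound 2 to compound 3 (beyond the scatter) while the 4-fluorophenyl group and the shared core stayed the same. Among the compounds shown here, the earlier step at this place had only swapped one thiazole for a differently substituted thiazole, so this is the first reading of a change in ring type itself, and measured against the 4-methyl-2-phenyl-1,3-thiazol-5-yl group, the oxadiazole gave a number 23.6 percentage points higher from compound 1 to compound 3 (beyond the scatter) in the same read-out. No measurement on hand explains either step, and the differing counts of hetero atoms and hydrogen-bond acceptors remain counts only.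

From the compounds shown here alone, it remains open whether the higher number holds when an amine or a carboxylic acid takes the place of the fluorine on the phenyl ring of the oxadiazole group, or when a longer chain carries that group on the amide-type nitrogen. Each compound here also has a reading at only one concentration, so these numbers give no potency.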